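A few compounds are considered here, and "the series" means these few. Any claim that something is new, unique, unknown or untested is made for them only; others in the source may bear on it.

Working notes on a small series read in a functional assay on L929 cells (Mus musculus) for antiproliferative activity, read by MTT assay; on this read-out higher numbers stand for weaker inhibition and lower numbers for stronger inhibition. Compound 1 `CC(C)(C)[Si](O[C@H]1C[C@H]2CC(=O)C[C@H]2C1)(c1ccccc1)c1ccccc1` gives only a limit, > 40 ug/mL, and no number. Compound 2 `C=C1C[C@@H]2CC3(C[C@@H]2C1)OCC(C)(C)CO3` also gives only a limit, > 40 ug/mL. Both measured compounds therefore stand at the same place, (the limit of > 40 ug/mL in this assay, at which 2 of the 2 values shown sit), and no order can be drawn between them.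

Compound 3 `CC(C)(C)[Si](OC1CCCCC1)(c1ccccc1)c1ccccc1` has not yet been measured. Its difference from compound 1 is a group of 6 heavy atoms (6 carbon; one six-membered non-aromatic ring of carbon only) in place of a group of 9 heavy atoms (8 carbon, 1 oxygen; 2 five-membered non-aromatic rings of carbon only), on an oxygen. In words, a cyclohexyl group replaces the group carrying two five-membered non-aromatic rings of carbon only, on an oxygen whose other neighbours are: silicon.

Within the data shown here, no measured step gives a size for such a change. Compound 1 sits at the limit of > 40 ug/mL, so it offers no number to step from, and no step beyond the usual scatter is expected in this assay, in either direction. The expected move is a step that the limit leaves unreadable from compound 1 to compound 3, and a limit is the likeliest report. For compound 3 the estimated value is 60 ug/mL, with an expected range of 30 ug/mL to 120 ug/mL.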

Compound 3, half-maximal inhibitory concentration: 40 ug/mL
Compound 3: middle estimate off by 1.5-fold (0.18 log units), on the high side; low and high end bracket the measured number.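

Replacing the group of compound 1 with cyclohexyl, on an oxygen whose other neighbours are: silicon, gives the only actual number among the compounds shown in this assay, with compound 3 at 40 ug/mL. Compound 1, at > 40 ug/mL, gives a limit of the assay and not a number. The change can therefore be read only as a number no higher from compound 1 to compound 3 (the limit leaves the size open), but it does show that a measurable value at this oxygen does not require the group with two five-membered rings and 3 defined stereocentres.

Whether cyclohexyl truly gives stronger inhibition than the group it replaces remains open, as does the size of any such gain, with the series still sitting at the edge of the read-out: the limit of > 40 ug/mL in this assay, at which 2 of the 3 values shown sit.

Also open, from the compounds shown here alone, is how this oxygen would respond to a longer chain such as hexyl, or to a cyclohexyl ring carrying an amine or a carboxylic acid, in place of the plain cyclohexyl of compound 3.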